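The source may report more compounds than this note shows. Statements on the series, on what has been measured and on what is new or still open speak of the compounds shown alone.

In a functional assay (on this read-out lower numbers stand for stronger inhibition and higher numbers for weaker inhibition), compound 1 (`CC(C)=CCOc1ccc2c(c1)OC(c1ccccc1F)CC2=O`) gives 6360 nM and compound 2 (`CC(C)=CCOc1ccc2c(c1)OC(c1ccc(F)cc1)CC2=O`) gives 7320 nM while compound 3 (`CC(C)=CCOc1ccc2c(c1)OC(c1ccc(Cl)cc1)CC2=O`) gives 6970 nM on the same core. Compound 3 therefore stands level with both of the others, and its two steps (a 1.1-fold higher number from compound 1 to compound 3 (0.04 log units; within the scatter) and a 1.1-fold lower number from compound 2 to compound 3 (0.02 log units; within the scatter)) separate it from neither. Among the compounds with values here, the next compound, compound 4 (`CC(C)=CCOc1ccc2c(c1)OC(c1ccccc1Br)CC2=O`), differs from compound 3 by 2-bromophenyl in place of 4-chlorophenyl on a saturated ring carbon as its one change: 2-bromophenyl in place of 4-chlorophenyl on a saturated ring carbon, next to the ring oxygen. Within the data shown here, three measured steps bear on this. Replacing 2-fluorophenyl with 4-fluorophenyl gave a 1.2-fold higher number from compound 1 to compound 2 (0.06 log units; within the scatter) and replacing it with 4-chlorophenyl gave a 1.1-fold higher number from compound 1 to compound 3 (0.04 log units; within the scatter) as well, so the halogen's place on the ring has not yet moved the number. Chloro in place of fluoro on an aromatic carbon gave a 1.1-fold lower number from compound 2 to compound 3 (0.02 log units; within the scatter) in the same way. Among the measured compounds shown here, no measured compound carries bromo, so that part of the change remains untested. From these steps no shift beyond the scatter is expected in this assay, and the expected step is a 1.0-fold lower number from compound 3 to compound 4 (0.01 log units; within the scatter) in this series. Compound 4 is estimated at 6800 nM (expected range 3500 nM to 13000 nM).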

Compound 4, half-maximal inhibitory concentration: 3180 nM
Compound 4: the middle estimate sits 2.1-fold (0.33 log units) above what was measured; the whole stated range lies above it.
By their numbers in this assay, from the lowest: compounds 4, 1, 3 and 2 (each within the scatter of the next, the first and the last beyond it).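

Within the data shown here, the saturated ring carbon next to the ring oxygen turns out not to be indifferent in this assay: 2-bromophenyl gives the first steps in this set that lie beyond the scatter, with a 2.2-fold lower number from compound 3 to compound 4 (0.34 log units; beyond the scatter) and a 2.3-fold lower number from compound 2 to compound 4 (0.36 log units; beyond the scatter) both modest in size. The separation is only partial, however, as a 2.0-fold lower number from compound 1 to compound 4 (0.30 log units; within the scatter) leaves compound 4 level with compound 1, which carries 2-fluorophenyl and itself stands level with compound 2 and compound 3, so compound 1 goes against any clean split of these four compounds into two groups. Nothing at hand explains why the number moves with this change.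

2-bromophenyl differs from 4-chlorophenyl in both the halogen and its place on the ring, and the compounds shown do not tell which of the two carries the step, a question that 4-bromophenyl and 2-chlorophenyl would bear on directly. Also open, from the compounds shown here alone, is whether the number at this position depends on a halogen at all, which unsubstituted phenyl or 2-methoxyphenyl would begin to address.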